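Imidazole to aminomethyl on the saturated ring carbon

The compounds below may be only part of what the source reports. "The series", "measured", "known", "first", "only" and "open" are said of these compounds alone.

Measured compounds, read in an assay on isolated protein for binding affinity to Alpha-1D adrenergic receptor (Rattus norvegicus), read by radioligand binding; on this read-out higher numbers stand for weaker inhibition and lower numbers for stronger inhibition:
Compound 1 `CS(=O)(=O)Nc1ccc(F)c2c1CCCC2c1c[nH]cn1`: 3020 nM
Compound 2 `CCS(=O)(=O)Nc1cccc(Cc2c[nH]cn2)c1C`: 1000 nM
Compound 3 `CCS(=O)(=O)Nc1cccc2c1CCCC2c1c[nH]c(C)n1`: < 10000 nM (a limit)

For compound 3 the result in this assay is a limit and not a number, (the limit of < 10000 nM in this assay, at which 1 of the 3 values shown sits). Among the measured compounds shown here, compound 3 therefore has no fixed place among the measured compounds; compound 1 and compound 2 are the only two with numbers, and those two numbers lie within the usual scatter of each other.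

Compound 4 `CCS(=O)(=O)Nc1cccc2c1CCCC2CN` is not yet measured in this assay. It differs from compound 3 in one place: aminomethyl in place of 2-methyl-1H-imidazol-4-yl on a saturated ring carbon. For the measured compounds named here, no pair of measured compounds covers a change of this kind; all three measured compounds carry a five-membered aromatic ring at that position, so nothing measured shows what a small acyclic amine does there. Going by the values given here, the step expected from compound 3 to compound 4 is a step that the limit leaves unreadable from compound 3 to compound 4, set in the direction of weaker binding and beyond the scatter, but it rests on no measured pair. Compound 4 is expected to give 6000 nM, with an estimated range from 1500 nM to 30000 nM.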

Compound 4, inhibition constant: < 10000 nM
Compound 4: only a limit was reported; the forecaster's own chance of this, stated with the estimate: 40%; the middle value lies beyond the limit too.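

No step from compound 3 to compound 4 can be read, because both results in this assay are limits: the limit of < 10000 nM in this assay, at which 2 of the 4 values shown sit.

The compounds shown leave open how far, and in which direction, aminomethyl in place of 2-methyl-1H-imidazol-4-yl on a saturated ring carbon shifts binding.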